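The compounds below may be only part of what the source reports. "The series", "measured", "known", "first", "only" and "open" are said of these compounds alone.

Compound 1 `CC(C)c1onc(-c2c(Cl)cccc2Cl)c1COc1ccc2cc(-c3cccc(C(=O)O)c3)sc2c1` gives 140 nM in an assay on isolated protein for binding affinity to Bile acid receptor (Homo sapiens), read by FRET; a lower number here means that less compound is needed, a higher number that more compound is needed for the effect. Compound 2 `CC(C)c1onc(-c2c(Cl)cccc2Cl)c1COc1ccc2cc(-c3ccc(C(=O)O)cc3)sc2c1`, which carries 4-carboxyphenyl in place of 3-carboxyphenyl on an aromatic carbon, gives 200 nM in this assay, and the step of a 1.4-fold higher number from compound 1 to compound 2 (0.15 log units; within the scatter) is within the scatter. Compound 3 `CC(C)c1onc(-c2c(Cl)cccc2Cl)c1COc1ccc2cc(-c3cccc(C(=O)O)c3)ccc2c1` gives 110 nM in this assay; how its core differs from that of compound 1 is not broken down here, and its values against compound 1 and compound 2 lie within the scatter.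

Compound 4 `CC(C)c1onc(-c2c(Cl)cccc2Cl)c1COc1ccc2cc(-c3ccc(C(=O)O)cc3)ccc2c1` is not yet measured and differs from compound 3 by 4-carboxyphenyl in place of 3-carboxyphenyl on an aromatic carbon. This is the same kind of change as that from compound 1 to compound 2, but the place differs: there it sat on an aromatic carbon of a five-membered aromatic ring with 1 sulfur, next to the ring sulfur; here it sits on a six-membered aromatic ring of carbon only, meta to a fused ring and para to a fused ring. Resting on compound 1 moving to compound 2 by a 1.4-fold higher number from compound 1 to compound 2 (0.15 log units; within the scatter), a step of a 1.4-fold higher number from compound 3 to compound 4 (0.13 log units; within the scatter) is expected for compound 4. Compound 4 is estimated at 150 nM, between 80 nM and 300 nM.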

Compound 4, half-maximal effective concentration: 440 nM
Compound 4: the middle estimate sits 2.9-fold (0.47 log units) below what was measured; measured number outside the range, above it.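

On the core of compound 3, 4-carboxyphenyl in place of 3-carboxyphenyl gives in this assay a 4.0-fold higher number from compound 3 to compound 4 (0.60 log units; beyond the scatter). The same change thus does not carry over in size from one core to the other: the same change on two cores in this assay, a 1.4-fold higher number (0.15 log units; within the scatter) from compound 1 to compound 2 and a 4.0-fold higher number (0.60 log units; beyond the scatter) from compound 3 to compound 4, 2.8-fold (0.45 log units) apart, beyond the scatter of two such steps. For the compounds shown here, this rests on one pair per core and shows only that the step differs between these two cores; it does not show which difference between the cores goes with the larger step.

From the compounds shown here alone, all four compounds carry a carboxylic acid, and how an amide or a tetrazole in its place would read in this assay stays open. Also open, going by these compounds, is whether a further core would follow the smaller step or the larger one.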